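The source may hold more compounds than are shown below. What is called first, only, known or untested is meant among the compounds shown, and "the series" means these compounds.

Measured so far: compound 1 `CCN(CC)CCNC(=O)c1ccc(C(CC)(CC)c2ccc(OCC(O)C(C)(C)C)c(C)c2)n1CC` gives 110 nM in an assay on HL-60 cells for agonist activity at vitamin D3 receptor (Homo sapiens), read by microscopy, with a stated time of 96 h; a lower number here means that less compound is needed, a higher number that more compound is needed for the effect; compound 2 `C#CCCOC(=O)c1ccc(C(CC)(CC)c2ccc(OCC(O)C(C)(C)C)c(C)c2)n1CC` gives 1030 nM in this assay; compound 3 `CCn1c(C(=O)Nc2ccc(OC(F)(F)F)cc2)ccc1C(CC)(CC)c1ccc(OCC(O)C(C)(C)C)c(C)c1` is reported in this assay only as > 50000 nM.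

Compound 3 thus stands at the weak end of the three: its value is a limit of the assay, not a number, and it sits at the limit of > 50000 nM in this assay, at which 1 of the 3 values shown sits. Compound 4 `CCn1c(C(=O)OCc2ccccn2)ccc1C(CC)(CC)c1ccc(OCC(O)C(C)(C)C)c(C)c1` differs from compound 3 in one place: (pyridin-2-yl)methoxy in place of (4-(trifluoromethoxy)phenyl)amino on a carbonyl carbon. Within the data shown here, two measured steps bear on this change. The step of an at least 48-fold higher number from compound 2 to compound 3 (1.68 log units; beyond the scatter) shows that replacing a (but-3-yn-1-yl)oxy group on the carbonyl carbon by the (4-(trifluoromethoxy)phenyl)amino group cost a great deal, and the step of an at least 450-fold higher number from compound 1 to compound 3 (2.65 log units; beyond the scatter) points the same way. Compound 4 returns to a carbonyl carbon bearing an oxygen-linked group, as in compound 2, so a large recovery is expected, roughly undoing the step from compound 2 to compound 3. Compound 4 is therefore expected to show the step of an at least 33-fold lower number from compound 3 to compound 4 (1.52 log units; beyond the scatter). Compound 4 is estimated at 1500 nM, with a range from 300 nM to 8000 nM.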

Compound 4, half-maximal effective concentration: > 50000 nM
Compound 4 was reported as a limit; the forecaster's own chance of this, stated with the estimate: 15%; middle value at least 33-fold (1.52 log units) away from the limit.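

An oxygen link on the carbonyl carbon does not by itself preserve activity: compound 4 carries one, as compound 2 does, yet its value is a limit of this assay, the same limit as for compound 3: the limit of > 50000 nM in this assay, at which 2 of the 4 values shown sit. The group on that oxygen therefore matters, as (pyridin-2-yl)methoxy in place of (but-3-yn-1-yl)oxy gives an at least 48-fold higher number from compound 2 to compound 4 (1.68 log units; beyond the scatter), while the change from the (2-(diethylamino)ethyl)amino group gives an at least 450-fold higher number from compound 1 to compound 4 (2.65 log units; beyond the scatter). Among these compounds, the two at the limit carry a six-membered aromatic ring in this group and the two with readable values carry none, though the step between the two limits cannot be read.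

On these data alone, how weak compound 3 and compound 4 really are remains open. So does whether a carboxylic acid or a piperidine on a short chain at this carbonyl carbon would give a readable value.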